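This account rests on a few compounds, and the source may have more. Where it says the series, first, only, none or still open, it means among the compounds named here.

Compound 1 `CCOC(=O)c1c(-c2cccc(OC)c2)[nH]c2cc(Cl)c(OC)cc2c1=O` and compound 2 `CCOC(=O)c1c(-c2cccc(Oc3ccccc3)c2)[nH]c2cc(Cl)c(OC)cc2c1=O` share one core; compound 3 `CCOC(=O)c1c(-c2cccc(OC)c2)[nH]c2cc(OC)c(Cl)cc2c1=O` and the still unmeasured compound 4 `CCOC(=O)c1c(-c2cccc(Oc3ccccc3)c2)[nH]c2cc(OC)c(Cl)cc2c1=O` share another, and the difference between the two cores is not broken down here. All were tested in an ADME assay on BJ cells (Homo sapiens) for cytotoxicity, read by luminescence, with a stated time of 72 h; a lower number here means that less compound is needed, a higher number that more compound is needed for the effect. Compound 1 gives > 21500 nM, which is a limit of the assay rather than a number. Compound 2 gives > 21500 nM, also a limit. Compound 3 gives > 21500 nM, again a limit. The change from compound 1 to compound 2 is phenyl in place of methyl on an oxygen on an aromatic ring, and its step is a step that the two limits leave unreadable from compound 1 to compound 2. The same change, (phenyl in place of methyl on an oxygen on an aromatic ring), turns compound 3 into compound 4. Since (the limit of > 21500 nM in this assay, at which 3 of the 3 values shown sit), compound 4 is expected to stay at that limit too, with an expected step that the limit leaves unreadable from compound 3 to compound 4. The estimate for compound 4 in this assay is therefore 25000 nM.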

Compound 4, half-maximal effective concentration: > 21500 nM
Compound 4: a limit, no number; the forecaster's own chance of this, stated with the estimate: 85%; the middle value does not contradict the limit.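

Compound 3 and compound 4 both stand at a limit of the assay rather than at a number, so no step can be read between them. The compounds shown leave open whether changing methoxy to phenoxy affects cytotoxicity at all.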